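A few compounds are considered here, and "the series" means these few. Any claim that something is new, unique, unknown or untested is made for them only; others in the source may bear on it.

Measured compounds in an assay on the whole organism (plasma, strain Sprague-Dawley) for inhibition of Dipeptidyl peptidase 4 (Rattus norvegicus), with a stated time of 10 h, at a dose of 1 mg/kg by the oral route; on this read-out lower numbers stand for less inhibition and higher numbers for more inhibition at the one dose given (going by the name of the read-out):
compound 1, `N#C[C@@H]1CCCN1C(=O)[C@@H]1C[C@H](C(=O)N2CCCCCCC2)CN1`: "not determined" (no result reported)
compound 2, `C[C@@H]1N[C@H](C(=O)N2CCC[C@H]2C#N)C[C@@H]1C(=O)N1CCC1`: 88%
compound 3, `N#C[C@@H]1CCCN1C(=O)[C@@H]1C[C@H](C(=O)N2CCCCCC2)CN1`: "not determined" (no result reported)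

Compound 1 stands without a number: in this assay compound 1 has "not determined" (no result reported). Compound 3 likewise has "not determined" (no result reported), so neither of the two larger ring amides offers a point of reference. Among the measured compounds shown here, the only number in the set comes from compound 2, which in this assay gives 88%.

The step from compound 1 to compound 4 changes the amide on the carbonyl carbon: a group of 4 heavy atoms (3 carbon, 1 nitrogen; one four-membered non-aromatic ring with 1 hetero atom) in place of a group of 8 heavy atoms (7 carbon, 1 nitrogen; one eight-membered non-aromatic ring with 1 hetero atom), on a carbonyl carbon. Compound 4, `N#C[C@@H]1CCCN1C(=O)[C@@H]1C[C@H](C(=O)N2CCC2)CN1`, therefore carries the azetidin-1-yl amide that compound 2 also carries, while the shared core of compound 1 is kept without the extra methyl of compound 2.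

For the measured compounds named here, since compound 1 has no value, the size and direction of the step to compound 4 cannot be given, and no step between measured compounds exists to lean on. The expectation for compound 4 rests only on compound 2 and is held loosely. Compound 4 is expected to give about 80% in this assay, with a range from 55% to 95%, because compound 2 gives 88% with the same azetidin-1-yl amide.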

Compound 4, a percentage reported as inhibition, in the whole organism at one dose (the size of the read-out at that dose, not a potency): 46%
Compound 4: the middle estimate sits 34 percentage points above what was measured, and the stated range ends above it.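

In this assay, two compounds that share the azetidin-1-yl amide do not give the same result: hydrogen in place of methyl on a saturated ring carbon amounts to a number 42 percentage points lower from compound 2 to compound 4 (beyond the scatter) and so marks this ring carbon as a place where a single methyl group goes with a large difference in the read-out at this dose and time. The amide alone therefore does not set the read-out here, which the lone earlier number could not show, while the step from the eight-membered ring amide of compound 1 to the azetidin-1-yl amide of compound 4 cannot be read, as compound 1 has no result, and compound 3 offers no comparison either. No measurement given here accounts for the difference between these two compounds.

The compounds shown leave open whether a longer chain such as ethyl, or a hydroxymethyl group, on that saturated ring carbon would go with a higher or a lower read-out than methyl or hydrogen. They also leave open whether the methyl group goes with a difference of similar size when the amide is the eight-membered ring or a piperidin-1-yl group instead of azetidin-1-yl.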